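This account rests on a few compounds, and the source may have more. Where it says the series, first, only, none or still open, it means among the compounds named here.

Measured compounds:
compound 1 `CNC(=O)c1cc(C(=O)N[C@H]2CC[C@H](O)CC2)c([C@@H](C)c2cccc(C)c2)o1`: 85 nm/s
compound 2 `CNC(=O)c1cc(C(=O)NC2CC2)cn([C@@H](C)c2ccccc2)c1=O`: 16 nm/s
compound 3 `CC[C@@H](c1ccccc1)n1nc(C(=O)NC)cc1C(=O)N[C@H]1[C@@H]2C[C@@H](O)C[C@@H]21`: 120 nm/s

In an ADME assay for permeability (on this read-out lower numbers stand for lower permeability and higher numbers for higher permeability), compound 1 gives 85 nm/s, the second highest of the three numbers. Compound 3 gives 120 nm/s, a number within the usual scatter of that of compound 1, so the two cannot be told apart. Compound 2 gives 16 nm/s, clearly lower than compound 1 and beyond the scatter.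

Compound 4 `CNC(=O)c1cc(C(=O)N[C@H]2CC[C@H](O)CC2)c([C@@H](C)c2ccc(C)cc2)o1` has not yet been measured in this assay. It differs from compound 1 in one place: 4-methylphenyl in place of 3-methylphenyl on a saturated chain carbon bound to an aromatic carbon and a saturated chain carbon. The same atoms are present, joined differently. For the measured compounds named here, no measured pair shows a change of this kind, so the only guide is how alike the two structures are. The step expected here, a 1.1-fold higher number from compound 1 to compound 4 (0.02 log units; within the scatter), is one within the scatter, in no clear direction. Compound 4 is expected to give about 90 nm/s, between 45 nm/s and 180 nm/s.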

Compound 4, apparent permeability: 108 nm/s
Estimate against measurement, compound 4: 1.2-fold (0.08 log units) below, within the range that was stated.
By their numbers in this assay, from the lowest: compound 2; then compounds 1, 4 and 3 (each within the scatter of the next).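

Moving the methyl group, from 3-methylphenyl in compound 1 to 4-methylphenyl in compound 4, gives a 1.3-fold higher number from compound 1 to compound 4 (0.10 log units; within the scatter) in this assay, so the two compounds cannot be told apart. For the compounds shown here, this is the first pair in the set that differs in one place, and it shows that this rearrangement of the same atoms produces no step that can be read beyond the scatter. No measurement shown here offers an explanation for this result.

Still open, as far as these compounds go, is what an amine or a carboxylic acid in place of the methyl group would give. This single pair also cannot show how the same swap would behave on another core.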